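The source may report more compounds than this note shows. Statements on the series, on what has been measured and on what is new or still open speak of the compounds shown alone.

Of the compounds shown here, two have been measured so far. Compound 1 `CCCCOc1ccc(C(C)N(O)C(=O)c2ccccc2)cc1` gives 1300 nM in an assay on RBL-1 cells for inhibition of Polyunsaturated fatty acid 5-lipoxygenase (Rattus norvegicus); a lower number here means a stronger inhibitor, a higher number a weaker inhibitor. Compound 2 `CCCCOc1ccc(CN(O)C(C)=O)cc1` gives 1100 nM in this assay. For the measured compounds named here, of these two numbers the one for compound 2 is the lower, but its gap to compound 1 lies within the usual scatter of repeated measurements, so on these figures the two compounds cannot be told apart. Going by the values given here, no pair of measured compounds differs in a single place, so no measured step is available to guide the next move.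

Compound 3 `CCCCOc1ccc(C(CCCC)N(O)C(C)=O)cc1` is the next compound to be measured. It differs from compound 2 in one place: butyl in place of hydrogen on a saturated chain carbon bound to an amide-type nitrogen and an aromatic carbon. Among the compounds with values here, with no measured step of this kind to lean on, the expectation rests only on the closeness of compound 1 and compound 2, which shows that the changes seen so far have left the numbers near each other. For compound 3 the step of a 1.8-fold lower number from compound 2 to compound 3 (0.26 log units; within the scatter) is expected to be small, towards a somewhat lower number, and possibly not beyond the scatter. Compound 3 is therefore expected to give 600 nM in this assay, with a range from 150 nM to 2500 nM.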

Compound 3, half-maximal inhibitory concentration: 570 nM
Compound 3: the middle estimate sits 1.1-fold (0.02 log units) above what was measured; measured number inside the range.
By their numbers in this assay, from the lowest: compounds 3, 2 and 1 (each within the scatter of the next, the first and the last beyond it).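

For the compounds shown here, this is the first measured step at this position: in this assay, putting butyl in place of hydrogen on a saturated chain carbon bound to an amide-type nitrogen and an aromatic carbon gives a 1.9-fold lower number from compound 2 to compound 3 (0.29 log units; within the scatter) and remains within the usual scatter. Compound 2 and compound 3 therefore cannot be told apart, even though the change adds a chain of 4 carbon atoms where there was only a hydrogen atom, so this position can carry a butyl group with no measured loss of inhibition. No other measurement bears on this step, so the data offer no explanation for it. As far as these compounds go, whether this position tolerates every group of this kind remains open, since a single step cannot show whether a methyl group, a longer chain such as hexyl, or a phenyl ring there would move the number beyond the scatter. From the compounds shown here alone, it is also open whether butyl would behave in the same way with the benzoyl group of compound 1 in place of the acetyl group on the nitrogen.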